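The source may hold more compounds than are shown below. What is called first, only, known or untested is meant among the compounds shown, and "the series" means these compounds.

Compounds measured so far:
Compound 1, `C/C(=C\c1ccc(C(=O)c2ccc3c(c2)C(C)(C)CCC3(C)C)cc1)C(=O)O`, gives 70% in a functional assay for activation of retinoic acid receptor beta (Homo sapiens); on this read-out lower numbers stand for smaller maximal responses and higher numbers for larger maximal responses.
Compound 2, `CC1(C)CCC(C)(C)c2cc(C(=O)c3ccc(C#CC(=O)O)cc3)ccc21`, gives 47% in this assay.

Compound 2 stands lowest of these two numbers; its nearest neighbour is compound 1, and the step of a number 23 percentage points lower from compound 1 to compound 2 (beyond the scatter) lies beyond the scatter. Compound 3, `CC1(C)CCC(C)(C)c2cc(C(=O)c3ccc(/C=C\C(=O)O)cc3)ccc21`, is the next candidate. Its difference from compound 2 is 2-carboxyethenyl in place of 2-carboxyethynyl on an aromatic carbon. For the measured compounds named here, the only measured step that bears on it is a number 23 percentage points lower from compound 1 to compound 2 (beyond the scatter), where a group with a double bond gave way to one with a triple bond and the maximal response fell. The change to compound 3 moves the other way, restoring a double bond in the side chain, though without the methyl of compound 1. A rise beyond the scatter, smaller than that earlier step, is therefore expected. For compound 3 the estimate in this assay is 58%, within 40% to 78%, meaning an expected step of a number 11 percentage points higher from compound 2 to compound 3 (beyond the scatter).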

Compound 3, largest response reached (reported as maximum), in percent of the reference or control that the assay uses: 41%
Beside the measured number, compound 3's estimate is 17 percentage points above it, and the stated range covers the measured number.
By their numbers in this assay, from the lowest: compounds 3 and 2 (each within the scatter of the next); then compound 1.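

In this assay, the 2-carboxyethenyl in place of the 2-carboxyethynyl on this aromatic carbon gives a number 6 percentage points lower from compound 2 to compound 3 (within the scatter) and so shows that a double bond in place of the triple bond does not by itself restore the response of compound 1. Compounds 1 and 3 both carry a double bond in the side chain, yet the change from 2-carboxyprop-1-en-1-yl to 2-carboxyethenyl gives a number 29 percentage points lower from compound 1 to compound 3 (beyond the scatter) and thus sets the group of compound 1 apart from both others at this position. Nothing available here accounts for this difference.

On these data alone, whether an ethyl group on the double bond would match the methyl of compound 1 remains open. So does how an amide or a tetrazole in place of the carboxylic acid would behave on the same core.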